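The source may hold more compounds than are shown below. What is called first, only, known or untested is meant among the compounds shown, and "the series" means these compounds.

Measured so far in a functional assay on CCRF-CEM cells (Homo sapiens) for cytotoxicity, read by XTT assay, with a stated time of 3 days; a lower number here means a stronger inhibitor, a higher number a weaker inhibitor:
compound 1 `OC[C@H]1O[C@@H](n2cc(F)c3c(-c4ccccc4)ncnc32)[C@H](O)[C@@H]1O`: 3100 nM
compound 2 `OC[C@H]1O[C@@H](n2cc(F)c3c(-c4nccs4)ncnc32)[C@H](O)[C@@H]1O`: 550 nM

Compound 1 gives the highest number of the two in this assay; its nearest neighbour is compound 2, which is reached by a 5.6-fold lower number from compound 1 to compound 2 (0.75 log units; beyond the scatter), a step beyond the scatter. Compound 3 `OC[C@H]1O[C@@H](n2cc(F)c3c(-c4ccsc4)ncnc32)[C@H](O)[C@@H]1O` has not yet been measured. It differs from compound 1 in one place: thiophen-3-yl in place of phenyl on an aromatic carbon. Within the data shown here, the only measured step that bears on this change is the one from compound 1 to compound 2, in which a five-membered aromatic ring likewise took the place of phenyl on the same aromatic carbon of the shared core; that step was a 5.6-fold lower number from compound 1 to compound 2 (0.75 log units; beyond the scatter). Thiophen-3-yl is a different five-membered ring from 1,3-thiazol-2-yl, so the size of that step is a guide rather than a rule. Among the measured compounds shown here, a lower number is expected from compound 1 to compound 3 in this assay, probably a smaller step than the one to compound 2, and the expected step is a 2.1-fold lower number from compound 1 to compound 3 (0.32 log units; beyond the scatter). The estimate for compound 3 in this assay is 1500 nM, with a range from 500 nM to 4500 nM.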

Compound 3, half-maximal inhibitory concentration: 560 nM
For compound 3 the middle estimate is 2.7-fold (0.43 log units) above the measured one, within the range that was stated.
By their numbers in this assay, from the lowest: compounds 2 and 3 (each within the scatter of the next); then compound 1.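

In this assay the exchange of phenyl for thiophen-3-yl gives a 5.5-fold lower number from compound 1 to compound 3 (0.74 log units; beyond the scatter) and so shows that the lower number at this aromatic carbon is not peculiar to 1,3-thiazol-2-yl: both five-membered aromatic rings shown here stand beyond the scatter from phenyl. Exchanging one five-membered ring for the other gives a 1.0-fold higher number from compound 2 to compound 3 (0.01 log units; within the scatter) and the assay does not separate them, even though the two rings differ in their ring atoms and in how they are attached to the shared core. Nothing at hand explains the difference from phenyl or the lack of one between the two five-membered rings.

Still open, from the compounds shown here alone, is whether the trend reaches other rings on this carbon, such as furan-2-yl or pyridin-2-yl, or whether it is lost with a non-aromatic group such as an amine or a short alkyl chain. Also open is whether the same ring order holds when the fluorine on the shared core gives way to chlorine or hydrogen, and in cell lines other than the one shown.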